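The source may report more compounds than this note shows. Statements on the series, on what has been measured and on what is new or still open speak of the compounds shown alone.

Compound 2 `O=C(O)c1csc(SCCN2C(=O)OC[C@@H]2/C=C/[C@@H](O)C2(CCCCF)CCC2)n1` gives 1080 nM in an assay on isolated protein for binding affinity to prostaglandin E2 receptor EP1 subtype (Homo sapiens) (on this read-out lower numbers stand for stronger inhibition and higher numbers for weaker inhibition), the top of the three numbers shown, though only its gap to compound 1 lies beyond the scatter. Compound 1 `CC(C)(CCCCF)[C@H](O)/C=C/[C@H]1COC(=O)N1CCSc1nc(C(=O)O)cs1` gives 431 nM in this assay, and compound 3 `O=C(O)c1csc(SCCN2C(=O)OC[C@@H]2/C=C/[C@@H](O)C2(CCc3ccccc3)CCC2)n1` gives 802 nM. The step of a 2.5-fold higher number from compound 1 to compound 2 (0.40 log units; beyond the scatter) exchanges the group on the carbon that carries the hydroxyl, while the step of a 1.3-fold lower number from compound 2 to compound 3 (0.13 log units; within the scatter) alters the end of the side chain on the ring. Compound 4 `COCCCC1([C@H](O)/C=C/[C@H]2COC(=O)N2CCSc2nc(C(=O)O)cs2)CCC1` has not yet been measured in this assay. Its difference from compound 2 is methoxy in place of fluoromethyl on a saturated chain carbon, three bonds along the chain from a saturated ring carbon. Of the two measured steps, the one that bears most directly on this change is the second, because a 1.3-fold lower number from compound 2 to compound 3 (0.13 log units; within the scatter) also replaces the outer part of the same chain and stayed within the scatter. The other step, a 2.5-fold higher number from compound 1 to compound 2 (0.40 log units; beyond the scatter), concerns a different position and was modest. On this basis the step from compound 2 to compound 4 is expected to be small, a 1.2-fold lower number from compound 2 to compound 4 (0.08 log units; within the scatter), with no clear direction beyond the scatter. Compound 4 is therefore estimated at 900 nM in this assay, with a range from 400 nM to 2000 nM.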

Compound 4, inhibition constant: > 10000 nM
Compound 4: only a limit was reported; the forecaster's own chance of this, stated with the estimate: 5%; middle value at least 11-fold (1.04 log units) from the limit.
By their numbers in this assay, from the lowest: compounds 1, 3 and 2 (each within the scatter of the next, the first and the last beyond it). At a limit, above all of these: compound 4.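

In this assay, compound 4 gives a limit and not a number: the limit of > 10000 nM in this assay, at which 1 of the 4 values shown sits. The exchange of 4-fluorobutyl for 3-methoxypropyl gives an at least 9.2-fold higher number from compound 2 to compound 4 (0.96 log units; beyond the scatter), which shows that this position, three bonds along the chain from a saturated ring carbon, does not accept every change at the outer end of the chain, although the earlier change to the phenyl end stayed within the scatter. The 3-methoxypropyl chain also separates compound 4 from the other two compounds, with an at least 12-fold higher number from compound 3 to compound 4 (1.09 log units; beyond the scatter) and an at least 23-fold higher number from compound 1 to compound 4 (1.36 log units; beyond the scatter), so that in this set of four the fluorine-ended and phenyl-ended chains sit together and the methoxy-ended chain alone sits at the limit.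

The compounds shown do not tell whether the loss belongs to the oxygen inside the chain or to the methyl group at its end, and a chain ending in a hydroxyl group or an ethoxy group would bear on that. Nor do they show how a plain butyl chain or a terminal amine would behave at this position.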